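A few compounds are considered here, and "the series" means these few. Any claim that something is new, unique, unknown or untested is made for them only; others in the source may bear on it.

In an assay on cells for inhibition of HSP60/HSP10 (Homo sapiens), with a stated time of 60 min (a higher number here means a weaker inhibitor, a lower number a stronger inhibitor), the measured compounds are these.
Compound 1, `O=S(=O)(Nc1ccc(-c2nc3ccccc3o2)cc1)c1ccc(Cl)s1`, gives 31000 nM.
Compound 2, `CCc1ccc(S(=O)(=O)Nc2ccc(-c3nc4ccccc4o3)cc2)cc1`, reaches only the limit > 100000 nM.
Compound 3, `C=Cc1ccc(S(=O)(=O)Nc2ccc(-c3nc4ccccc4o3)cc2)cc1`, likewise reaches only the limit > 100000 nM.

Compound 3 therefore stands at the ceiling of this assay: its value is a limit, not a number, and the limit of > 100000 nM in this assay, at which 2 of the 3 values shown sit, is the point at which it and one further value sit. Compound 4 is `O=S(=O)(Nc1ccc(-c2nc3ccccc3o2)cc1)c1ccccc1Cl` and has not yet been measured. The change from compound 3 to compound 4 is 2-chlorophenyl in place of 4-vinylphenyl on a sulfonyl sulfur. For the measured compounds named here, two measured steps bear on it: an at least 3.2-fold higher number from compound 1 to compound 2 (0.50 log units; beyond the scatter) and an at least 3.2-fold higher number from compound 1 to compound 3 (0.50 log units; beyond the scatter), both leading from the 5-chlorothiophen-2-yl of compound 1 to 4-ethylphenyl or 4-vinylphenyl and both weakening inhibition by at least a modest amount. The step from compound 2 to compound 3 is a step that the two limits leave unreadable from compound 2 to compound 3, so vinyl against ethyl cannot be read. Compound 4 puts a chlorine-substituted aromatic ring back on the sulfonyl sulfur, as in compound 1, so the direction of those two steps is expected to reverse, and the expected step is an at least 2.5-fold lower number from compound 3 to compound 4 (0.39 log units; beyond the scatter). The estimate for compound 4 in this assay is 40000 nM, expected between 12000 nM and 130000 nM, while a limit remains a real possibility.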

Compound 4, half-maximal inhibitory concentration: > 100000 nM
Compound 4: a limit, no number; the forecaster's own chance of this, stated with the estimate: 35%; at least 2.5-fold (0.39 log units) between middle value and limit.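

Moving to a 2-chlorophenyl on the sulfonyl sulfur does not retain the measurable inhibition that compound 1 shows in this assay, and the change reads as an at least 3.2-fold higher number from compound 1 to compound 4 (0.50 log units; beyond the scatter). Compound 4 gives > 100000 nM, which is a limit of the assay and not a number. Among the compounds shown, a chlorine on a phenyl ring is therefore not enough to give a number: the 2-chlorophenyl of compound 4 ends at the same limit as the 4-ethylphenyl of compound 2 and the 4-vinylphenyl of compound 3, so the steps among these three cannot be read, and compound 1 remains the only one with a number: the limit of > 100000 nM in this assay, at which 3 of the 4 values shown sit.

On these data alone, it remains open whether the number for compound 1 depends on the thiophene ring itself or on its chlorine, and whether a thiophene without chlorine or a pyridine ring on the sulfonyl sulfur would also give a number. As far as these compounds go, how compound 2, compound 3 and compound 4 differ from one another also stays unknown, as does the effect of an amine or a carboxylic acid on the ring.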